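The source may report more compounds than this note shows. Statements on the series, on what has been measured and on what is new or still open speak of the compounds shown alone.

Measured so far in a functional assay on G55T2 cells (Homo sapiens) for antiproliferative activity, read by WST assay, with a stated time of 72 h; on this read-out higher numbers stand for weaker inhibition and lower numbers for stronger inhibition:
Compound 1 `O=C(CCN(Cc1ccc(C(=O)NO)cc1)C(=O)c1ccccc1)NCc1ccccc1`: 5940 nM
Compound 2 `COc1cc(OC)cc(C(=O)N(CCC(=O)NCc2ccccc2)Cc2ccc(C(=O)NO)cc2)c1`: 14700 nM
Compound 3 `COc1ccc(C(=O)N(CCC(=O)NCc2ccccc2)Cc2ccc(C(=O)NO)cc2)cc1`: 3490 nM

Within the data shown here, only one of the two steps reaching compound 3 goes beyond the scatter: a 4.2-fold lower number from compound 2 to compound 3 (0.62 log units; beyond the scatter). The next structure, compound 4 `Cc1ccc(C(=O)N(CCC(=O)NCc2ccccc2)Cc2ccc(C(=O)NO)cc2)cc1`, carries methyl in place of methoxy on an aromatic carbon, para to a large group: methyl in place of methoxy on an aromatic carbon. The nearest guide is a 1.7-fold lower number from compound 1 to compound 3 (0.23 log units; within the scatter), since it also concerns methoxy on an aromatic carbon. The larger 2.5-fold higher number from compound 1 to compound 2 (0.39 log units; beyond the scatter) involves 3,5-dimethoxyphenyl, a different group, so it bears less. No step beyond the scatter is therefore expected in this assay. The expected change is a 1.2-fold higher number from compound 3 to compound 4 (0.08 log units; within the scatter). Compound 4 is estimated at about 4200 nM, with an expected range of 2200 nM to 8000 nM.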

Compound 4, half-maximal inhibitory concentration: 690 nM
For compound 4 the middle estimate is 6.1-fold (0.78 log units) above the measured one; the whole stated range lies above it.
By their numbers in this assay, from the lowest: compound 4; then compounds 3 and 1 (each within the scatter of the next); then compound 2.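

In this assay, the ring position para to a large group turns out to be sensitive to which group sits there: methyl in place of methoxy gives a 5.1-fold lower number from compound 3 to compound 4 (0.70 log units; beyond the scatter), while methoxy in place of hydrogen had given only a 1.7-fold lower number from compound 1 to compound 3 (0.23 log units; within the scatter). Methyl in place of hydrogen gives an 8.6-fold lower number from compound 1 to compound 4 (0.93 log units; beyond the scatter), and 4-methylphenyl in place of 3,5-dimethoxyphenyl gives a 21-fold lower number from compound 2 to compound 4 (1.33 log units; beyond the scatter). Nothing available explains why this small swap has such an effect.

As far as these compounds go, whether an ethyl group, a chlorine atom or an amine at this position would lower the number further remains open.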